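This account rests on a few compounds, and the source may have more. Where it says the series, first, only, none or still open, it means among the compounds named here.

Measured so far:
compound 1, `CC1CCN(C2CCN(S(=O)(=O)c3cn(C)cn3)CC2)CC1`: > 5000 nM
compound 2, `CC1CCN(C2CCN(S(=O)(=O)c3cccc(-c4ccc(Cl)cc4)c3)CC2)CC1`: 15 nM
compound 3, `COc1cc(C)ccc1S(=O)(=O)N1CCC(N2CCC(C)CC2)CC1`: > 5000 nM

In a functional assay on DLD-1 cells (Homo sapiens) for antiproliferative activity, read by CellTiter-Glo, with a stated time of 72 h (on this read-out lower numbers stand for stronger inhibition and higher numbers for weaker inhibition), compound 1 gives only > 5000 nM, which is a limit of the assay and not a number. Compound 1 therefore stands at the limit of > 5000 nM in this assay, at which 2 of the 3 values shown sit. Compound 3 likewise gives only > 5000 nM, a limit. Compound 2 gives 15 nM in this assay. Compound 4, `Cc1ccc(S(=O)(=O)N2CCC(N3CCC(C)CC3)CC2)cc1C`, has not yet been measured; it differs from compound 1 by 3,4-dimethylphenyl in place of 1-methyl-1H-imidazol-4-yl on a sulfonyl sulfur. Within the data shown here, no pair of measured compounds differs in a single place, so the direction of this step is open. Among the measured compounds shown here, compound 3 also carries a small substituted phenyl on the sulfonyl sulfur and sits at the limit, while the only potent compound, compound 2, carries a much larger substituent. Compound 4 is expected to give about 3000 nM, within 300 nM to 10000 nM, and may again come back only as a limit. That expectation means an at least 1.6-fold lower number from compound 1 to compound 4 (0.22 log units; that floor lies within the scatter).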

Compound 4, half-maximal inhibitory concentration: 24 nM
For compound 4 the middle estimate is 130-fold (2.10 log units) above the measured one; measured number below the stated range.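

In this assay, among these compounds, the group on the sulfonyl sulfur proves decisive for this core: putting 3,4-dimethylphenyl in place of 1-methyl-1H-imidazol-4-yl gives an at least 200-fold lower number from compound 1 to compound 4 (2.31 log units; beyond the scatter), and the earlier compounds offered no such single change to read. On these data alone, the true size of this step stays unknown, since it starts from a limit of the assay and not a number: the limit of > 5000 nM in this assay, at which 2 of the 4 values shown sit. The compounds shown leave open whether both methyl groups of the 3,4-dimethylphenyl are needed, and how a plain phenyl or a pyridine ring would read on the same sulfonyl sulfur.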